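Sulfonyl Substituent Change on a Prostaglandin D2 Receptor Antagonist

The source may report more compounds than this note shows. Statements on the series, on what has been measured and on what is new or still open speak of the compounds shown alone.

Measured so far:
compound 1, `Cc1ccc(S(=O)(=O)CCO)cc1C#Cc1cc(Cl)ccc1OCC(=O)O`, 19 nM
compound 2, `Cc1ccc(S(=O)(=O)N2CCOCC2)cc1C#Cc1cc(Cl)ccc1OCC(=O)O`, 3.6 nM

In an assay on CHO cells for displacement of a labelled ligand from prostaglandin D2 receptor 2 (Homo sapiens), read by scintillation counting (a lower number here means a stronger inhibitor, a higher number a weaker inhibitor), compound 2 gives the lower of the two numbers, and compound 1 gives 19 nM. Within the data shown here, the one step between them, a 5.3-fold lower number from compound 1 to compound 2 (0.72 log units; beyond the scatter), shows that the group on the sulfonyl sulfur matters here. Compound 3, `Cc1ccc(S(=O)(=O)N(C)C)cc1C#Cc1cc(Cl)ccc1OCC(=O)O`, has not yet been tested. It differs from compound 2 in just one place: dimethylamino in place of morpholin-4-yl on a sulfonyl sulfur. Among the measured compounds shown here, no measured pair shows this exact change, so the only guide is the size of a 5.3-fold lower number from compound 1 to compound 2 (0.72 log units; beyond the scatter), which came from a different group at the same place. Compound 3 is expected to stay near compound 2, with at most a modest loss, so the estimate is 6 nM, between 2.5 nM and 15 nM, meaning a 1.7-fold higher number from compound 2 to compound 3 (0.22 log units; within the scatter).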

Compound 3, inhibition constant: 5 nM
Compound 3: the middle estimate sits 1.2-fold (0.08 log units) above what was measured; the range from low to high includes it.
By their numbers in this assay, from the lowest: compounds 2 and 3 (each within the scatter of the next); then compound 1.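

In this assay, morpholin-4-yl with its six-membered ring can give way to dimethylamino, which has no ring, and the outcome is a 1.4-fold higher number from compound 2 to compound 3 (0.14 log units; within the scatter). The ring and its oxygen are therefore not needed to hold the number at this level on the sulfonyl sulfur. Dimethylamino also keeps most of the advantage over 2-hydroxyethyl, with a 3.8-fold lower number from compound 1 to compound 3 (0.58 log units; beyond the scatter), so both compounds with a nitrogen on the sulfur, compound 2 and compound 3, give lower numbers than compound 1, which has a carbon chain there.

No supporting evidence is available to explain these differences. A simple ethyl group on the sulfur would help to separate the effect of the nitrogen from that of the hydroxyl, while piperidine would test a ring without the oxygen.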